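Bromo for chloro on the para-substituted phenyl ring

This account rests on a few compounds, and the source may have more. Where it says the series, first, only, none or still open, it means among the compounds named here.

Compound 1 `Oc1cccc(C(c2c[nH]c3ccc(Br)cc23)c2c[nH]c3ccc(Br)cc23)c1`: 8000 nM
Compound 2 `Clc1ccc(C(c2c[nH]c3ccc(Br)cc23)c2c[nH]c3ccc(Br)cc23)cc1`: 8500 nM

In a functional assay on A549 cells (Homo sapiens) for inhibition, read by MTT assay, with a stated time of 48 h (a lower number here means a stronger inhibitor, a higher number a weaker inhibitor), compound 2 stands at 8500 nM, within the scatter of compound 1. Compound 3 `Brc1ccc(C(c2c[nH]c3ccc(Br)cc23)c2c[nH]c3ccc(Br)cc23)cc1` differs from compound 2 in one place: bromo in place of chloro on an aromatic carbon. This puts bromo in place of chloro on an aromatic carbon, para to a large group. Going by the values given here, the only measured step, a 1.1-fold higher number from compound 1 to compound 2 (0.03 log units; within the scatter), exchanged a larger piece of the molecule and stayed within the scatter, so no step beyond the scatter is expected here. The expected change is a 1.1-fold lower number from compound 2 to compound 3 (0.03 log units; within the scatter). For compound 3 the estimated value is 8000 nM, with an expected range of 4000 nM to 16000 nM.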

Compound 3, half-maximal inhibitory concentration: 5600 nM
Compound 3: the middle estimate sits 1.4-fold (0.15 log units) above what was measured; low and high end bracket the measured number.
By their numbers in this assay, from the lowest: compounds 3, 1 and 2 (each within the scatter of the next).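

Within this assay, bromo in place of chloro on the aromatic carbon (a 1.5-fold lower number from compound 2 to compound 3 (0.18 log units; within the scatter)) is a step within the scatter, so this exchange of one halogen for the other does not tell compound 2 and compound 3 apart. The larger exchange of 3-hydroxyphenyl for 4-bromophenyl (a 1.4-fold lower number from compound 1 to compound 3 (0.15 log units; within the scatter)) also stays within the scatter. No evidence is available that bears on these results.

As far as these compounds go, whether an amine or a carboxylic acid in place of the bromo would give a step beyond the scatter remains open. The same question holds for a methoxy group.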